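Cytotoxicity notes: nitro to amino in compound 1

The source may report more compounds than this note shows. Statements on the series, on what has been measured and on what is new or still open speak of the compounds shown alone.

Measured so far:
compound 1 `COc1cc(OC)c(/C=C/S(=O)(=O)Cc2ccc(OC)c([N+](=O)[O-])c2)c(OC)c1` — 2910 nM
compound 2 `COc1ccc(CS(=O)(=O)CC(=O)Nc2c(C)cc(C)cc2C)cc1N` — > 30000 nM

Within the data shown here, compound 1 gives the only plain number here in an ADME assay on MRC5 cells (Homo sapiens) for cytotoxicity, read by MTT assay, with a stated time of 72 h (a higher number here means a weaker inhibitor of growth, a lower number a stronger inhibitor of growth), 2910 nM. For compound 2 the value in this assay is a limit of the assay, > 30000 nM. Compound 3 `COc1cc(OC)c(/C=C/S(=O)(=O)Cc2ccc(OC)c(N)c2)c(OC)c1` is not yet measured; it differs from compound 1 by amino in place of nitro on an aromatic carbon. No step between measured compounds is shown. Compound 2, which also carries an amino group, sits at the limit of > 30000 nM in this assay, at which 1 of the 2 values shown sits, so for compound 3 an upward step in this assay beyond the scatter is expected, a 4.1-fold higher number from compound 1 to compound 3 (0.62 log units; beyond the scatter). The estimate for compound 3 in this assay is 12000 nM, within 3500 nM to 40000 nM.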

Compound 3, concentration for 50% growth inhibition: 80 nM
The estimate for compound 3 lay 150-fold (2.18 log units) above the measured number; the whole stated range lies above it.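

In this assay, amino in place of nitro on an aromatic carbon, ortho to a methoxy group, gives a 36-fold lower number from compound 1 to compound 3 (1.56 log units; beyond the scatter). Among these compounds, this is the first step that can be read: on the shared core, this position responds strongly to this change, and compound 3 is the stronger inhibitor of growth. Nothing on hand accounts for the size of this step. As far as these compounds go, it remains open whether a hydroxyl group or an acetamide at the same position would behave like amino or like nitro. From the compounds shown here alone, whether the same change has a similar effect on a different core also remains open.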